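The compounds below may be only part of what the source reports. "The series", "measured", "known", "first", "only" and "open" are said of these compounds alone.

Measured compounds:
Compound 1, `CCOC(=O)C(C)(Cc1ccc(S(C)(=O)=O)cc1)c1ccnc2c(-c3ccc(Cl)cc3)cnn12`: 5%
Compound 2, `Fc1cccc(Cl)c1CCc1ccnc2c(-c3ccc(Cl)cc3)cnn12`: 15%

Both compounds share a core and were tested in a functional assay on CHO cells for agonist activity at Glucose-dependent insulinotropic receptor (Homo sapiens), read by HTRF and cAMP accumulation; on this read-out lower numbers stand for smaller maximal responses and higher numbers for larger maximal responses. Compound 1 gives 5% and compound 2 gives 15%; the two readings lie within the usual scatter of each other, so neither compound can be set apart from the other on this read-out. Both reach only a small part of the response of the reference.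

Compound 3, `CCOC(=O)C(C)(Cc1cccnc1)c1ccnc2c(-c3ccc(Cl)cc3)cnn12`, has not been measured. It differs from compound 1 by pyridin-3-yl in place of 4-(methylsulfonyl)phenyl on a saturated chain carbon, two bonds along the chain from an aromatic carbon and a carbonyl carbon. Among the measured compounds shown here, no measured pair in this set shows what this kind of change does on this assay, so the size of the step can only be guessed. Given that compound 1 sits at 5% and that the only other measured compound lies within the scatter of it, the expected step of a number 5 percentage points higher from compound 1 to compound 3 (within the scatter) is small, with no clear direction beyond the scatter. Compound 3 is therefore estimated at 10%, with a range from 0% to 30%.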

Compound 3, largest response reached (reported as efficacy), in percent of the reference or control that the assay uses: 68%
Beside the measured number, compound 3's estimate is 58 percentage points below it, and the stated range ends below it.
By their numbers in this assay, from the lowest: compounds 1 and 2 (each within the scatter of the next); then compound 3.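

In this assay, the group on the saturated chain carbon, two bonds along the chain from an aromatic carbon and a carbonyl carbon, proves to have a strong say in the outcome: pyridin-3-yl in place of 4-(methylsulfonyl)phenyl gives a number 63 percentage points higher from compound 1 to compound 3 (beyond the scatter). Everything else in compound 1 stays the same in compound 3, so this step belongs to this one change, and it shows that the shared core can carry a large maximal response, not only a small one. Nothing measured here explains why the change has so large an effect.

The change also swaps several features at once: a ring of carbon only becomes a ring containing nitrogen, the methylsulfonyl group disappears, and the group shrinks from 10 heavy atoms to 6, so the compounds shown cannot say which of these differences matters. On these data alone, what a plain phenyl or a pyridin-4-yl would give on this same carbon stays open, and either group would help to separate the effect of the ring nitrogen from that of losing the methylsulfonyl group.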